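This account rests on a few compounds, and the source may have more. Where it says the series, first, only, none or still open, it means among the compounds named here.

Measured compounds:
Compound 1, `c1ccc(Cc2nnc(-c3c[nH]c4ccccc34)o2)cc1`: in a functional assay on PC-3 cells (Homo sapiens) for cytotoxicity, read by MTT assay (a lower number here means a stronger inhibitor, a higher number a weaker inhibitor), compound 1 gives > 1000000 nM, which is a limit of the assay and not a number (the limit of > 1000000 nM in this assay, at which 1 of the 3 values shown sits).
Compound 2, `c1cncc(-c2nnc(-c3c[nH]c4ccccc34)o2)c1`: in this assay compound 2 gives 711000 nM.
Compound 3, `Clc1ccc(-c2nnc(-c3c[nH]c4ccccc34)o2)cc1`: in this assay compound 3 gives 41600 nM.

Compound 3 stands at the lowest of the two numbers given; its nearest neighbour is compound 2, and the step of a 17-fold lower number from compound 2 to compound 3 (1.23 log units; beyond the scatter) lies beyond the scatter. The step of an at least 24-fold lower number from compound 1 to compound 3 (1.38 log units; beyond the scatter) is also large. Both steps show that the 4-chlorophenyl group on the shared core is where the low number of compound 3 comes from.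

Compound 4, `FC(F)(F)c1nnc(-c2c[nH]c3ccccc23)o1`, differs from compound 3 in one place: trifluoromethyl in place of 4-chlorophenyl on an aromatic carbon. For the measured compounds named here, no measured step replaces the 4-chlorophenyl with a group that has no ring, so the two large steps into compound 3 are the only guide, and both point the same way: exchanging the 4-chlorophenyl for something else raises the number. A step upward, likely beyond the scatter, is therefore expected from compound 3 to compound 4, a 9.6-fold higher number from compound 3 to compound 4 (0.98 log units; beyond the scatter). For compound 4 the value expected in this assay is 400000 nM, with a range from 60000 nM to 1000000 nM.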

Compound 4, half-maximal inhibitory concentration: > 1000000 nM
Compound 4 ended at the assay's limit; the forecaster's own chance of this, stated with the estimate: 35%; middle value at least 2.5-fold (0.39 log units) from the limit.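

In this assay compound 4 stands at a limit of the assay and not at a number: the limit of > 1000000 nM in this assay, at which 2 of the 4 values shown sit.

For the compounds shown here, for the first time a group without a ring occupies this aromatic carbon of the shared core, and the change gives an at least 24-fold higher number from compound 3 to compound 4 (1.38 log units; beyond the scatter), so trifluoromethyl does not retain the low number of compound 3. The comparison with pyridin-3-yl is less informative, giving an at least 1.4-fold higher number from compound 2 to compound 4 (0.14 log units; that floor lies within the scatter), which sets no order between those two compounds, and the step between the two compounds at the limit cannot be read.

Still open, as far as these compounds go, is whether the low number of compound 3 depends on the chlorine or on the phenyl ring itself, a question that a plain phenyl or a 4-fluorophenyl group would address. From the compounds shown here alone, it is also open whether any group without a ring, such as an amine or a longer alkyl chain, could give a number below the limit at this position.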